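Cyclohexyl to 4-cyanophenyl on the aryl ether oxygen

This account rests on a few compounds, and the source may have more. Where it says the series, first, only, none or still open, it means among the compounds named here.

Compound 1 `N[C@@H](COP(=O)(O)OCCCOC(=O)CCc1ccccc1OCc1cccc(OC2CCCCC2)c1)C(=O)O` and compound 2 `N[C@@H](COP(=O)(O)OCCCOC(=O)CCc1ccccc1OCc1cccc(Oc2ccc(F)cc2)c1)C(=O)O` are the two measured compounds. In an assay on cells for agonist activity at probable G-protein coupled receptor 34 (Mus musculus), with a stated time of 1 h (on this read-out lower numbers stand for smaller maximal responses and higher numbers for larger maximal responses), compound 1 gives 18.8%, and compound 2 gives 18.7%, so compound 1 stands level with compound 2. Within the data shown here, the step of a number 0.1 percentage points lower from compound 1 to compound 2 (within the scatter) is the one measured change at this position. Compound 3 `N#Cc1ccc(Oc2cccc(COc3ccccc3CCC(=O)OCCCOP(=O)(O)OC[C@H](N)C(=O)O)c2)cc1` differs from compound 1 by 4-cyanophenyl in place of cyclohexyl on an oxygen on an aromatic ring. Because a number 0.1 percentage points lower from compound 1 to compound 2 (within the scatter) from a related exchange at the same oxygen stayed inside the scatter, the estimated step of a number 0.2 percentage points higher from compound 1 to compound 3 (within the scatter) in this assay is expected to be none beyond the scatter. Compound 3 is therefore expected to reach 19%, between 9% and 31%.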

Compound 3, largest response reached (Emax), in percent of the reference or control that the assay uses: 18.3%
Estimate against measurement, compound 3: 0.7 percentage points above; the range from low to high includes it.
By their numbers in this assay, from the lowest: compounds 3, 2 and 1 (each within the scatter of the next).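

In this assay, 4-cyanophenyl in place of cyclohexyl gives a number 0.5 percentage points lower from compound 1 to compound 3 (within the scatter), so a second substituted phenyl on this oxygen, alongside 4-fluorophenyl, stands level with cyclohexyl. Cyano in place of fluoro on the aromatic carbon gives a number 0.4 percentage points lower from compound 2 to compound 3 (within the scatter), so this exchange on the outer ring also shows no difference beyond the scatter. Nothing available here explains why these numbers stay level. The compounds shown leave open whether an amine or a carboxylic acid on that outer ring, or a longer chain on the oxygen, would take the response beyond the scatter.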